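This account rests on a few compounds, and the source may have more. Where it says the series, first, only, none or still open, it means among the compounds named here.

In a functional assay on MCF7 cells (Homo sapiens) for antiproliferative activity, read by sulforhodamine B assay, with a stated time of 48 h (on this read-out higher numbers stand for weaker inhibition and lower numbers for stronger inhibition), compound 1 `CC(=O)Nc1ccc(S(=O)(=O)Oc2ccccc2C(C)C)cc1` gives 16000 nM. Compound 2 `CC(C)c1ccccc1OS(=O)(=O)c1ccc(NC(=O)NCCCCl)cc1` gives 7400 nM in this assay, and the step of a 2.2-fold lower number from compound 1 to compound 2 (0.33 log units; beyond the scatter) is the only measured one in this set; compound 2 therefore stands at the lowest of the two numbers, with compound 1 as its nearest neighbour. Compound 3 `CC(C)c1ccccc1OS(=O)(=O)c1ccc(NC(=O)NC2CCCC2)cc1` has not been measured. It differs from compound 2 by cyclopentyl in place of 3-chloropropyl on an amide-type nitrogen. Within the data shown here, no measured step bears directly on this exchange: the one step known, from compound 1 to compound 2, replaced methyl on a carbonyl carbon with (3-chloropropyl)amino and does not tell how the urea substituent itself matters. Without a guiding precedent, the expected step of no change at the digits printed from compound 2 to compound 3 (within the scatter) is estimated to stay within the scatter. Compound 3 is therefore estimated at 7400 nM, with a range from 3000 nM to 18000 nM.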

Compound 3, half-maximal inhibitory concentration: 6200 nM
Compound 3: middle estimate off by 1.2-fold (0.08 log units), on the high side; the measured number falls inside the stated range.
By their numbers in this assay, from the lowest: compounds 3 and 2 (each within the scatter of the next); then compound 1.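

In this assay, an open chain and a ring on this amide-type nitrogen cannot be told apart: the exchange of 3-chloropropyl for cyclopentyl gives a 1.2-fold lower number from compound 2 to compound 3 (0.08 log units; within the scatter), so the chlorine of the chain is not required for a reading at this level. Cyclopentylamino in place of methyl on the carbonyl carbon gives a 2.6-fold lower number from compound 1 to compound 3 (0.41 log units; beyond the scatter), which shows that the modest difference from compound 1 is also seen with a substituent that carries no chlorine. Nothing in the available data explains these results.

The compounds shown leave open whether a phenyl or cyclohexyl ring on this nitrogen would give a number beyond the scatter of those for compound 2 and compound 3. They also leave open how a longer alkyl chain, or a chain ending in an amine or a carboxylic acid, would read out here.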